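Fluoro in Place of Methyl: Expected Cytotoxicity of Compound 3

The source may hold more compounds than are shown below. What is called first, only, known or untested is meant among the compounds shown, and "the series" means these compounds.

Two compounds have been measured in a functional assay on MCF7 cells (Homo sapiens) for cytotoxicity, read by MTT assay, with a stated time of 72 h; on this read-out higher numbers stand for weaker inhibition and lower numbers for stronger inhibition:

Compound 2 `COc1cc2nc(-c3ccc(-n4c(C)ccc4-c4ccc(C)cc4)cc3)sc2c(OC)c1OC` gives 3110 nM.
Compound 1 `COc1ccc2nc(-c3ccc(-n4c(C)ccc4-c4ccc([N+](=O)[O-])cc4)cc3)sc2c1` gives 4520 nM.

Compound 2 stands at the lower of the two numbers, but compound 1 lies within the scatter of it, so the two cannot be ranked. Compound 3 `COc1cc2nc(-c3ccc(-n4c(C)ccc4-c4ccc(F)cc4)cc3)sc2c(OC)c1OC` differs from compound 2 by fluoro in place of methyl on an aromatic carbon. Going by the values given here, no measured pair shows this change, so no step in this assay can be read from the data. The expected step from compound 2 to compound 3, a 1.1-fold higher number from compound 2 to compound 3 (0.05 log units; within the scatter), is none beyond the scatter. Compound 3 is therefore estimated at 3500 nM, within 1500 nM to 8000 nM.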

Compound 3, half-maximal inhibitory concentration: 2910 nM
Compound 3: middle estimate off by 1.2-fold (0.08 log units), on the high side; the measured number falls inside the stated range.
By their numbers in this assay, from the lowest: compounds 3, 2 and 1 (each within the scatter of the next).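

In this assay, fluoro in place of methyl on an aromatic carbon para to a large group gives a 1.1-fold lower number from compound 2 to compound 3 (0.03 log units; within the scatter), so compound 2 and compound 3 cannot be ranked. Going by these compounds alone, this is the first pair differing in one place, and it shows that going from 4-methylphenyl to 4-fluorophenyl produces no step that can be told from the scatter. No measurement shown here bears on the reason for this result.

From the compounds shown here alone, it remains open whether an amine or a carboxylic acid on this aromatic carbon would give a step beyond the scatter. Going by these compounds, it also remains open whether the same exchange would give a similar step on the core of compound 1.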